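A few compounds are considered here, and "the series" means these few. Any claim that something is new, unique, unknown or untested is made for them only; others in the source may bear on it.

Two sulfonamides were measured in a functional assay on A2780 cells (Homo sapiens) for cytotoxicity, read by MTT assay, with a stated time of 72 h; on this read-out higher numbers stand for weaker inhibition and lower numbers for stronger inhibition. Compound 1 `Cc1ccc(S(=O)(=O)Nc2cccc3[nH]nc(Br)c23)cc1` gives 70900 nM, and compound 2 `CCOc1ccc(NS(=O)(=O)c2ccc(C)cc2)c2cn[nH]c12` gives 55100 nM; these two numbers lie within the usual scatter of each other, so compound 2 stands alongside compound 1 rather than apart from it. Compound 3 `CCOc1ccc(NS(=O)(=O)c2ccc(C)cc2)c2c(Br)n[nH]c12` differs from compound 2 by one change: bromo in place of hydrogen on an aromatic carbon. Among the measured compounds shown here, no step between measured compounds is known for this change, so from compound 2 to compound 3 no shift beyond the scatter is expected, and the estimated step is a 1.4-fold lower number from compound 2 to compound 3 (0.14 log units; within the scatter). Compound 3 is therefore expected to give 40000 nM, within a range from 15000 nM to 100000 nM.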

Compound 3, half-maximal inhibitory concentration: 10500 nM
Beside the measured number, compound 3's estimate is 3.8-fold (0.58 log units) above it; the whole stated range lies above it.
By their numbers in this assay, from the lowest: compound 3; then compounds 2 and 1 (each within the scatter of the next).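

Among the compounds shown here, neither compound 1 nor compound 2 hinted at this: each carries only one of the two groups, and their numbers lie within the scatter of each other. With both groups on the shared core, the numbers separate: bromo on the aromatic carbon next to the ring nitrogen gives a 5.2-fold lower number from compound 2 to compound 3 (0.72 log units; beyond the scatter), and ethoxy gives a 6.8-fold lower number from compound 1 to compound 3 (0.83 log units; beyond the scatter). Each step was thus read with the other group already in place.

As far as these compounds go, whether a chloro group or an amine at the bromo position would do the same remains open. Nothing measured here explains either step.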